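The source may hold more compounds than are shown below. What is called first, only, known or untested is meant among the compounds shown, and "the series" means these compounds.

Measured compounds:
compound 1, `CCCC(=O)OCc1ccc2oc(=O)c(C(=O)Oc3cccc(Br)c3)cc2c1`, gives 24.7%.
compound 2, `CCCCCC(=O)OCc1ccc2oc(=O)c(C(=O)Oc3cccc(Br)c3)cc2c1`, gives 33.9%.
compound 3, `CCCCCCC(=O)OCc1ccc2oc(=O)c(C(=O)Oc3cccc(Br)c3)cc2c1`, gives 36%.

These three numbers come from a functional assay on HT-1080 cells (Homo sapiens), read by transwell migration, with a stated time of 24 h, tested at 10 uM; on this read-out higher numbers stand for a weaker effect at the one concentration tested and lower numbers for a stronger effect. Compound 3 stands at the top of the three: its number sits a number 2.1 percentage points higher from compound 2 to compound 3 (within the scatter) and a number 11.3 percentage points higher from compound 1 to compound 3 (beyond the scatter), so only the gap to compound 1 counts as a real difference.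

The next compound, compound 4, `CC(C)C(=O)OCc1ccc2oc(=O)c(C(=O)Oc3cccc(Br)c3)cc2c1`, differs from compound 3 in one place: isopropyl in place of hexyl on a carbonyl carbon. The measured steps all concern the same carbonyl-linked chain. Going from compound 1 outward, a number 9.2 percentage points higher from compound 1 to compound 2 (within the scatter) and a number 11.3 percentage points higher from compound 1 to compound 3 (beyond the scatter), while the small extra step a number 2.1 percentage points higher from compound 2 to compound 3 (within the scatter). The chain grew longer in each of those steps and the number drifted higher, that is, the effect grew weaker, with the full change from compound 1 to compound 3 just beyond the scatter. In compound 4 the chain is cut back to three carbons, much as in compound 1, so the step in this assay is expected to run the other way, toward a lower number, by an amount near the gap between compound 1 and compound 3. For compound 4 a value of 26% is estimated, within 16% to 37%, a step expected to be a number 10 percentage points lower from compound 3 to compound 4 (within the scatter).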

Compound 4, a percentage reported as activity, at one concentration (the size of the read-out at that concentration, not a potency): 21.1%
The estimate for compound 4 lay 4.9 percentage points above the measured number, and the stated range covers the measured number.
By their numbers in this assay, from the lowest: compounds 4, 1, 2 and 3 (each within the scatter of the next, the first and the last beyond it).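

Replacing the longer straight chains on this carbonyl carbon with isopropyl moves the number toward a stronger effect in this assay: hexyl to isopropyl gives a number 14.9 percentage points lower from compound 3 to compound 4 (beyond the scatter), and pentyl to isopropyl gives a number 12.8 percentage points lower from compound 2 to compound 4 (beyond the scatter). The new comparison is with propyl, the straight form of this branched group, and that swap gives a number 3.6 percentage points lower from compound 1 to compound 4 (within the scatter), so branching at this position has no effect that can be told apart from the scatter, and the short chains of compound 1 and compound 4 read alike. Nothing available here explains why the shorter groups sit apart from the longer ones.

The compounds shown carry only open carbon chains on this carbonyl carbon, so it remains open how a methyl group, a more heavily branched tert-butyl group, a ring such as cyclohexyl or phenyl, or a chain ending in an amine or a carboxylic acid would read here. On these data alone, it also remains open whether branching a longer chain, as in a branched form of pentyl or hexyl, would give a different result from branching this short one.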